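The source may report more compounds than this note shows. Statements on the series, on what has been measured and on what is new or still open speak of the compounds shown alone.

Measured so far:
compound 1, `COc1ccc2nc(C)cc(OCC(=O)Nc3cccc(C)c3)c2c1`, 39800 nM
compound 2, `COc1ccc2nc(C)cc(OCC(=O)Nc3ccc(Cl)c(C(F)(F)F)c3)c2c1`, 79400 nM

In a toxicity assay on HepG2 cells (Homo sapiens) for inhibition, read by CellTiter-Glo, with a stated time of 48 h (a lower number here means a stronger inhibitor, a higher number a weaker inhibitor), compound 1 gives 39800 nM, which is the lower of the two numbers recorded. Its nearest neighbour is compound 2, which gives 79400 nM in this assay; the gap between these two values lies within the usual scatter of repeated runs, so the two compounds cannot be told apart on the numbers alone. Both sit in the weak range of this assay.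

Compound 3, `COc1ccc2nc(C)cc(OCC(=O)Nc3ccccn3)c2c1`, has not yet been measured in this assay. It is reached from compound 1 by a single change: pyridin-2-yl in place of 3-methylphenyl on an amide-type nitrogen. Among the compounds with values here, no pair of measured compounds that differ in one place is available, so there is no directly comparable step to lean on. On what the two measured compounds show, both far into the weak range, the expectation is that this change produces no step beyond the scatter, with the estimated step from compound 1 to compound 3 in this assay being a 1.3-fold higher number from compound 1 to compound 3 (0.10 log units; within the scatter). For compound 3 the estimated value in this assay is 50000 nM, with a range from 15000 nM to 160000 nM.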

Compound 3, half-maximal inhibitory concentration: > 100000 nM
Compound 3 ended at the assay's limit; the forecaster's own chance of this, stated with the estimate: 25%; at least 2.0-fold (0.30 log units) between middle value and limit.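

In this assay, within the data shown here, pyridin-2-yl in place of 3-methylphenyl on the amide-type nitrogen gives the first step that can be read, an at least 2.5-fold higher number from compound 1 to compound 3 (0.40 log units; beyond the scatter). Compound 3 gives > 100000 nM, which is a limit of the assay and not a number. The two earlier compounds offered no step at this position, whereas this change shows a direction, towards a weaker number in a range that was already weak, though only a lower bound on its size can be given from a single value sitting at the limit: the limit of > 100000 nM in this assay, at which 1 of the 3 values shown sits.

The change removes the methyl group and brings a ring nitrogen in at the same time, and the compounds shown do not separate these two parts, which a plain phenyl on the same amide-type nitrogen could begin to do. They also leave open how this assay would read for a pyridine carrying a methyl group, or for a phenyl ring carrying an amine or a carboxylic acid, in this same place on the core of compound 1.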